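Trimming the aryl amide of compound 2

A few compounds are considered here, and "the series" means these few. Any claim that something is new, unique, unknown or untested is made for them only; others in the source may bear on it.

In a functional assay on CAKI-1 cells (Homo sapiens) for inhibition, read by sulforhodamine B assay, with a stated time of 48 h (on this read-out lower numbers stand for stronger inhibition of growth and higher numbers for weaker inhibition of growth), compound 1 `COc1cc(-c2nn(-c3cccc(NC(=O)Nc4ccc(Cl)c(Cl)c4)c3)cc2-c2ccncc2)ccc1Cl` gives 3700 nM. Compound 2 `COc1cc(-c2nn(-c3cccc(NC(=O)c4ccc(Cl)c(C(F)(F)F)c4)c3)cc2-c2ccncc2)ccc1Cl` reaches only the limit of > 32500 nM in this assay, so its value is not a number. The step of an at least 8.7-fold higher number from compound 1 to compound 2 (0.94 log units; beyond the scatter) is the only measured one, and it ends at the limit of > 32500 nM in this assay, at which 1 of the 2 values shown sits. Compound 3 `COc1cc(-c2nn(-c3cccc(NC(=O)c4ccccc4)c3)cc2-c2ccncc2)ccc1Cl` differs from compound 2 by phenyl in place of 4-chloro-3-(trifluoromethyl)phenyl on a carbonyl carbon. For the measured compounds named here, no measured step bears on this change, and compound 2 offers only a limit, so no direction can be read from the data. Compound 3 is expected to give about 30000 nM, estimated between 10000 nM and 100000 nM. The expected step of an at least 1.0-fold lower number from compound 2 to compound 3 (0.03 log units; that floor lies within the scatter) is estimated to stay within the scatter.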

Compound 3, concentration for total growth inhibition: > 100000 nM
Compound 3 ended at the assay's limit; the forecaster's own chance of this, stated with the estimate: 55%; at least 3.3-fold (0.52 log units) between middle value and limit.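

With phenyl on the carbonyl carbon, compound 3 also gives no number, only a limit of the assay: the limit of > 100000 nM in this assay, at which 1 of the 3 values shown sits. The step of an at least 27-fold higher number from compound 1 to compound 3 (1.43 log units; beyond the scatter) shows that dropping both the chlorines and the amino link leaves compound 3 well short of compound 1. Compound 2 and compound 3 both rest on limits, so the step between them cannot be read, and the data do not show whether the two chlorine-bearing substituents on the ring matter in the amide series. From the compounds shown here alone, it stays open whether an unsubstituted phenylamino group on this carbonyl carbon would restore a measurable value, and whether a benzyl group or a carboxylic acid on the phenyl ring would do so.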